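The compounds below may be only part of what the source reports. "The series", "measured", "known", "first", "only" and "open" are said of these compounds alone.

Measured in an ADME assay on Caco-2 cells (Homo sapiens) for permeability, read by LC-MS, in the apical to basolateral direction, with a stated time of 60 min, at pH 6.5; a lower number here means that the compound crosses the layer more slowly, a higher number that the compound crosses the layer faster:

- Compound 1 `CC(C)(C)OC[C@@H](O)C(=O)N1[C@H](C(=O)NCc2cc(Cl)ccc2-n2cnnn2)C[C@@H]2C[C@@H]21` gives 4.5 10^-6 cm/s
- Compound 2 `O=C(NCc1cc(Cl)ccc1-n1cnnn1)[C@@H]1CC=NN1C(=O)[C@H](O)c1ccccc1F` gives 8.9 10^-6 cm/s

Compound 2, at 8.9 10^-6 cm/s, stands within the usual scatter of compound 1, at 4.5 10^-6 cm/s. Compound 3 `CC(C)(C)[C@@H](O)C(=O)N1N=CC[C@H]1C(=O)NCc1cc(Cl)ccc1-n1cnnn1` has not yet been measured. It differs from compound 2 by tert-butyl in place of 2-fluorophenyl on a saturated chain carbon bound to a carbonyl carbon and an oxygen on a saturated carbon, with tert-butyl in place of 2-fluorophenyl on a saturated chain carbon bound to a carbonyl carbon and an oxygen on a saturated carbon. Going by the values given here, no measured pair shows this change, so no step beyond the scatter is expected in this assay. The expected step is a 1.4-fold lower number from compound 2 to compound 3 (0.14 log units; within the scatter). Compound 3 is estimated at 6.5 10^-6 cm/s, with an expected range from 2.5 10^-6 cm/s to 15 10^-6 cm/s.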

Compound 3, apparent permeability: 15 10^-6 cm/s
The estimate for compound 3 lay 2.3-fold (0.36 log units) below the measured number, and the stated range covers the measured number.
By their numbers in this assay, from the lowest: compounds 1, 2 and 3 (each within the scatter of the next, the first and the last beyond it).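

At the saturated chain carbon bound to a carbonyl carbon and an oxygen on a saturated carbon, tert-butyl in place of 2-fluorophenyl gives a 1.7-fold higher number from compound 2 to compound 3 (0.23 log units; within the scatter) in this assay. This first pair differing in one place shows that, in this assay, the six-membered aromatic ring at this position can be exchanged for a group with no ring without a step beyond the scatter. Nothing shown explains this result.

The compounds shown leave open how an isopropyl group, an amine or a carboxylic acid at this position would compare with compound 3. They also leave open whether the same exchange would give a similar step on the core of compound 1.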